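Methyl on the Pyridine Ring of Pyridine Thiosemicarbazones

The source may hold more compounds than are shown below. What is called first, only, known or untested is meant among the compounds shown, and "the series" means these compounds.

Of the compounds shown here, three have been tested in a functional assay on HeLa cells (Homo sapiens) for cytotoxicity, read by MTT assay, with a stated time of 72 h, tested at 1 uM; a higher number here means more inhibition of growth at the concentration tested, a lower number less inhibition of growth. Compound 1 `N/C(=N\NC(=S)N1CCCCCC1)c1ccccn1` gives 21.3% in this assay, and compound 2 `N/C(=N\NC(=S)N1CCCCC1)c1ccccn1` gives 15.5% in this assay. How the cores of compound 1 and compound 2 differ is not broken down here. Compound 3 `Cc1cccc(/C(N)=N/NC(=S)N2CCCCCC2)n1` gives 49.5% in this assay. Compound 3 arises from compound 1 by one change, (methyl in place of hydrogen on an aromatic carbon), and this change made a step of a number 28.2 percentage points higher from compound 1 to compound 3 (beyond the scatter).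

Compound 4 `Cc1ccnc(/C(N)=N/NC(=S)N2CCCCC2)c1` has not yet been measured. It arises from compound 2 by the change (methyl in place of hydrogen on an aromatic carbon). Among the measured compounds shown here, this is the same kind of change as the one from compound 1 to compound 3, but not the same: in compound 3 the methyl sits next to the ring nitrogen, whereas in compound 4 it sits opposite the ring nitrogen. For the measured compounds named here, only one measured example of a methyl entering the ring exists, and it is at a different place.

The step from compound 2 to compound 4 is estimated at a number 14.5 percentage points higher from compound 2 to compound 4 (beyond the scatter), smaller than the earlier one, because a number 28.2 percentage points higher from compound 1 to compound 3 (beyond the scatter) was measured at another place on the ring and cannot be carried over directly. Compound 4 is therefore expected to give about 30% in this assay. The range for compound 4 is estimated from 12% to 52%.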

Compound 4, percent growth inhibition at one concentration: 15.3%
The estimate for compound 4 lay 14.7 percentage points above the measured number; measured number inside the range.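

In this assay, placing a methyl on the aromatic ring, opposite the ring nitrogen, changed nothing that can be told apart from ordinary assay noise: the result is a number 0.2 percentage points lower from compound 2 to compound 4 (within the scatter). So the same kind of change does not bring a fixed gain that can simply be carried from one core to another in this series, as the two measured cases show: the same change on two cores in this assay, a number 28.2 percentage points higher (beyond the scatter) from compound 1 to compound 3 and a number 0.2 percentage points lower (within the scatter) from compound 2 to compound 4, 28.4 percentage points apart, beyond the scatter of two such steps. This does not show that the core alone decides the outcome, since the two steps differ both in the core and in where the methyl sits on the ring, and two examples cannot separate these two differences or support a general rule.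

The compounds shown leave open whether the larger step goes with the place of the methyl on the ring, with the core that carries it, or with the two together. They also leave open how a group other than methyl, such as an ethyl group, a methoxy group or an amine, would behave at either place on the ring of these cores.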